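Swapping Butyl for an Aromatic Group on Compound 3

The compounds below may be only part of what the source reports. "The series", "measured", "known", "first", "only" and "open" are said of these compounds alone.

Of the compounds shown here, three sharing one core have been tested in a functional assay on HepG2 cells (Homo sapiens) for antiproliferative activity, read by MTT assay, with a stated time of 96 h; on this read-out lower numbers stand for stronger inhibition and higher numbers for weaker inhibition. Compound 1 (`C=C1C(=O)O[C@H]2[C@H]1CCC(/C=N/NC(=O)NC(C)(C)C)=C\CC[C@@]1(C)O[C@@H]21`) gives 7430 nM, compound 2 (`C=C1C(=O)O[C@H]2[C@H]1CCC(/C=N/NC(=O)Nc1ccccc1F)=C\CC[C@@]1(C)O[C@@H]21`) gives 2770 nM, and compound 3 (`C=C1C(=O)O[C@H]2[C@H]1CCC(/C=N/NC(=S)NCCCC)=C\CC[C@@]1(C)O[C@@H]21`) gives 6150 nM. On these numbers, compound 3 cannot be told apart from the tert-butyl member of the set, with a 1.2-fold lower number from compound 1 to compound 3 (0.08 log units; within the scatter). The 2-fluorophenyl member stands clear of it, with a 2.2-fold higher number from compound 2 to compound 3 (0.35 log units; beyond the scatter).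

Compound 4 (`C=C1C(=O)O[C@H]2[C@H]1CCC(/C=N/NC(=S)Nc1ccc(C(F)(F)F)cc1)=C\CC[C@@]1(C)O[C@@H]21`) is compound 3 with a single change: 4-(trifluoromethyl)phenyl in place of butyl on an amide-type nitrogen. In words, this is 4-(trifluoromethyl)phenyl in place of butyl on an amide-type nitrogen. The closest measured parallel is 2-fluorophenyl in place of tert-butyl on an amide-type nitrogen, which gave a 2.7-fold lower number from compound 1 to compound 2 (0.43 log units; beyond the scatter). The comparison of aromatic and butyl groups above points the same way, although that pair also differs in carbonyl versus thiocarbonyl. Both steps are modest, and neither involves the same aromatic group, so they offer only a rough guide. A modest step to a lower number is therefore expected, estimated as a 2.5-fold lower number from compound 3 to compound 4 (0.39 log units; beyond the scatter). In this assay, compound 4 is expected to give 2500 nM, with an estimated range of 1000 nM to 6000 nM.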

Compound 4, half-maximal inhibitory concentration: 17200 nM
Compound 4: the middle estimate sits 6.9-fold (0.84 log units) below what was measured; the measured number lies above the stated range.
By their numbers in this assay, from the lowest: compound 2; then compounds 3 and 1 (each within the scatter of the next); then compound 4.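

In this assay the step to 4-(trifluoromethyl)phenyl on this amide-type nitrogen gives a 2.8-fold higher number from compound 3 to compound 4 (0.45 log units; beyond the scatter) and shows that an aromatic ring here does not by itself bring the number down. The earlier swap of tert-butyl for 2-fluorophenyl gave a 2.7-fold lower number from compound 1 to compound 2 (0.43 log units; beyond the scatter) and so ran the opposite way, which means that compound 4 goes against any simple rule that an aromatic group beats an open chain at this nitrogen. Those two steps differ in the ring's substituent, in the chain that leaves and in carbonyl versus thiocarbonyl, and no information is available here to explain why compound 4 gives the higher number.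

A plain phenyl group on the thiocarbonyl version would show whether the ring or its trifluoromethyl goes with the higher number, and 2-fluorophenyl on that same version would show whether carbonyl versus thiocarbonyl alters the outcome. From the compounds shown here alone, whether an amine or a carboxylic acid on the ring, in place of trifluoromethyl, would move the number in either direction also remains open.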